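The source may hold more compounds than are shown below. What is called first, only, known or untested is meant among the compounds shown, and "the series" means these compounds.

In a functional assay on RKO cells (Homo sapiens) for cytotoxicity, read by resazurin assay, with a stated time of 72 h (on this read-out higher numbers stand for weaker inhibition and lower numbers for stronger inhibition), the measured compounds are:

compound 1, `Cc1nccn1-c1csc(Nc2cccc(Br)c2)n1`: > 100000 nM, a limit of the assay and not a number;
compound 2, `COc1ccc(Nc2nc(-n3c(C)nc4ccccc43)cs2)cc1`: 52500 nM;
compound 3, `Cc1cn(-c2csc(Nc3cccc(Br)c3)n2)c(C)n1`: > 100000 nM, again a limit of the assay.

Compound 3 and compound 1 share a core and differ by hydrogen in place of methyl on an aromatic carbon; the resulting step that the two limits leave unreadable from compound 3 to compound 1 cannot be read, since both values sit at the limit of > 100000 nM in this assay, at which 2 of the 3 values shown sit. Compound 2 is the only one of the three with a number. Compound 4, `COc1ccc(Nc2nc(-n3cnc4ccccc43)cs2)cc1`, differs from compound 2 by hydrogen in place of methyl on an aromatic carbon. This is the same kind of change as that from compound 3 to compound 1, but not the same: here the carbon lies in a five-membered aromatic ring with 2 nitrogen that is part of a fused or bridged system of two rings, between two ring nitrogen atoms and next to the ring atom that bears a large group, whereas in compound 3 it lies next to the ring nitrogen, two ring bonds from the ring atom that bears a large group and two ring bonds from the ring atom that bears a methyl group. The difference between the core of compound 2 and the core of compound 3 is not broken down here.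

Because the earlier step that the two limits leave unreadable from compound 3 to compound 1 is unreadable, the expectation for compound 4 rests on compound 2 alone, whose value in this assay is 52500 nM. For compound 4 a step of a 1.1-fold higher number from compound 2 to compound 4 (0.06 log units; within the scatter) is expected, set beside the earlier one. Compound 4 is estimated at 60000 nM, expected to fall between 20000 nM and 150000 nM.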

Compound 4, half-maximal inhibitory concentration: > 100000 nM
Compound 4: no number, only a limit (the forecaster's own chance of this, stated with the estimate: 25%); at least 1.6-fold (0.22 log units) between middle value and limit.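

In this assay, hydrogen in place of methyl on the aromatic carbon between two ring nitrogen atoms gives an at least 1.9-fold higher number from compound 2 to compound 4 (0.27 log units; that floor lies within the scatter). As far as these compounds go, compound 4 gives > 100000 nM, which is a limit of the assay and not a number, so the step has only a floor and its true size stays unknown. The same kind of change from compound 3 to compound 1 cannot be read, so the series does not show whether the change carries from one core to another, and no comparison of the two steps is possible because the values gather at a single limit: the limit of > 100000 nM in this assay, at which 3 of the 4 values shown sit.

Going by these compounds alone, compound 2 remains the only compound with a number, so it stays open how an amine, an ethyl group or a longer chain in place of that methyl would shift the value. From the compounds shown here alone, it also stays open whether the change from methyl to hydrogen would read the same on a core where both partners give numbers in this assay.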